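The source may report more compounds than this note shows. Statements on the series, on what has been measured and on what is new or still open speak of the compounds shown alone.

Measured so far:
compound 1 `Cc1cc(CNc2cc(Br)cc3[nH]ncc23)ccc1O` gives 28% in an assay for inhibition of Indoleamine 2,3-dioxygenase 1 (Homo sapiens), with a stated time of 1 h, tested at 10 uM; on this read-out higher numbers stand for more inhibition at the one concentration tested (going by the name of the read-out) and lower numbers for less inhibition
compound 2 `Brc1cc(NCc2ccco2)c2cn[nH]c2c1` gives 29% in this assay

For the measured compounds named here, compound 2 and compound 1 differ in more than one place, so no single step between them is counted; their two numbers lie within the scatter of each other, and compound 2 cannot be set apart from compound 1 on this read-out. Both sit at a modest level of inhibition at the single concentration tested.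

Compound 3 `Brc1cc(NCc2cnc[nH]2)c2cn[nH]c2c1` is the next compound and has not yet been measured in this assay. Against compound 2 the change is 1H-imidazol-5-yl in place of furan-2-yl on a saturated chain carbon bound to a nitrogen on an aromatic ring. Going by the values given here, no step between measured compounds exists here to show how a change at this place moves the read-out, so the expectation rests on the shared core alone, which in compound 1 and compound 2 carries similar numbers. Compound 3 is therefore expected to change little: the estimated step of a number 1 percentage points higher from compound 2 to compound 3 (within the scatter) is small, in no fixed direction, and within the scatter. Compound 3 is estimated at 30%, with a range from 10% to 55%.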

Compound 3, a percentage reported as inhibition, at one concentration (the size of the read-out at that concentration, not a potency): 16%
Compound 3: middle estimate off by 14 percentage points, on the high side; the range from low to high includes it.
By their numbers in this assay, from the lowest: compound 3; then compounds 1 and 2 (each within the scatter of the next).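

For the compounds shown here, compound 3 gives the first single change that can be read at this place, on a saturated chain carbon bound to a nitrogen on an aromatic ring. In this assay, putting 1H-imidazol-5-yl in place of furan-2-yl gives a number 13 percentage points lower from compound 2 to compound 3 (beyond the scatter), so the read-out is sensitive to the group held at this position. Both groups have 5 heavy atoms and one five-membered aromatic ring, while 1H-imidazol-5-yl has 2 hetero atoms and 1 hydrogen-bond donor against 1 hetero atom and 0 hydrogen-bond donors for furan-2-yl, and nothing available explains why the number moves with this exchange.

Going by these compounds alone, the single step cannot separate the added ring nitrogen from the added hydrogen-bond donor, nor show whether the same exchange would move the read-out in the same way on another core. It also leaves open how this assay would respond at this place to a thiophen-2-yl group, with sulfur as its ring hetero atom, to a 1-methylimidazolyl group, with the ring hydrogen-bond donor capped by methyl, or to a longer chain carrying the furan-2-yl ring.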